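The source may report more compounds than this note shows. Statements on the series, on what has been measured and on what is new or still open speak of the compounds shown alone.

Series notes, a functional assay on LoVo cells (Homo sapiens) for inhibition, read by MTT assay, with a stated time of 24 h; a higher number here means a weaker inhibitor, a lower number a stronger inhibitor:

- compound 1 `CC1(C)[C@H]2CC[C@]1(C)N(Cc1cn(-c3cccc(Cl)c3)nn1)C(=O)C2` gives 70 nM
- compound 2 `CC1(C)[C@H]2CC[C@]1(C)N(Cc1cn(-c3ccccc3O)nn1)C(=O)C2` gives 540 nM
- compound 3 `CC1(C)[C@H]2CC[C@]1(C)N(Cc1cn(-c3ccc(F)cc3)nn1)C(=O)C2` gives 40 nM

Compound 3 has the lowest number of the three; compound 1 is nearest, with a 1.8-fold lower number from compound 1 to compound 3 (0.24 log units; within the scatter), while compound 2 is furthest, with a 14-fold lower number from compound 2 to compound 3 (1.13 log units; beyond the scatter). Compound 4 `CC1(C)[C@H]2CC[C@]1(C)N(Cc1cn(-c3cccc(Br)c3)nn1)C(=O)C2` is not yet measured in this assay. The change from compound 3: 3-bromophenyl in place of 4-fluorophenyl on an aromatic nitrogen. For the measured compounds named here, no measured step swaps one halogen aryl for another at a different ring site other than the step from compound 1 to compound 3, where the 3-chlorophenyl and 4-fluorophenyl compounds sit within the scatter of each other. Going by the values given here, the 3-bromophenyl group has no direct precedent here. A small step, if any, is expected for compound 4, a 1.5-fold higher number from compound 3 to compound 4 (0.18 log units; within the scatter), likely toward the number of compound 1. The estimate for compound 4 is 60 nM, within 25 nM to 150 nM.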

Compound 4, half-maximal inhibitory concentration: 30 nM
Compound 4: the middle estimate sits 2.0-fold (0.30 log units) above what was measured; low and high end bracket the measured number.
By their numbers in this assay, from the lowest: compounds 4, 3 and 1 (each within the scatter of the next, the first and the last beyond it); then compound 2.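

In this assay, for the compounds shown here, bromo in place of chloro on an aromatic carbon gives a 2.3-fold lower number from compound 1 to compound 4 (0.37 log units; beyond the scatter) and is the first halogen-only change, showing that the halogen identity on this aryl group can shift the number beyond the scatter. Across a change of both halogen and ring site, 3-bromophenyl in place of 4-fluorophenyl gives a 1.3-fold lower number from compound 3 to compound 4 (0.12 log units; within the scatter) and leaves the two compounds together, while an 18-fold lower number from compound 2 to compound 4 (1.26 log units; beyond the scatter) keeps the 2-hydroxyphenyl compound apart from all three halogen aryl compounds. No measurement here gives a reason for these steps.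

Still open, as far as these compounds go, is whether 3-iodophenyl extends the step from 3-chlorophenyl to 3-bromophenyl. From the compounds shown here alone, the effect of 3-methoxyphenyl or 3-aminophenyl on the aromatic nitrogen is also open.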